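The compounds below may be only part of what the source reports. "The series", "measured", "known", "first", "only" and "open" are said of these compounds alone.

Series notes. Compound 1 `N=C(NCc1ccc(O)cc1)[C@@H]1CCC(=O)N1Cc1ccccc1`, compound 2 `COc1ccc(CNC(=N)[C@@H]2CCC(=O)N2Cc2ccccc2)cc1` and compound 3 `COc1ccc(CN2C(=O)CC[C@H]2C(=N)NCc2ccc(O)cc2)cc1` have been run in a functional assay on SH-SY5Y cells (Homo sapiens) for cytotoxicity, read by MTT assay, with stated times of 8 h, 30 min and 12 h, tested at 5 uM; on this read-out higher numbers stand for a stronger effect at the one concentration tested and lower numbers for a weaker effect. Compound 1 gives 37.6% in this assay, compound 2 gives 19.5%, and compound 3 gives 26.6%. The change from compound 1 to compound 2 is methyl in place of hydrogen on an oxygen on an aromatic ring, and it gave a number 18.1 percentage points lower from compound 1 to compound 2 (beyond the scatter). The cores of compound 1 and compound 3 differ by methoxy in place of hydrogen on an aromatic carbon, which gave a number 11 percentage points lower from compound 1 to compound 3 (beyond the scatter). Compound 2 and compound 3 lie within the scatter of each other, so no order is drawn between them.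

Compound 4 `COc1ccc(CNC(=N)[C@@H]2CCC(=O)N2Cc2ccc(OC)cc2)cc1` has not yet been measured in this assay. It is related to compound 3 by methyl in place of hydrogen on an oxygen on an aromatic ring, the same change as from compound 1 to compound 2, occurring twice in this set with the same surroundings at the place of change. The step expected from this change, resting on the earlier a number 18.1 percentage points lower from compound 1 to compound 2 (beyond the scatter), is estimated as a number 14.6 percentage points lower from compound 3 to compound 4 (beyond the scatter). The lower starting point of compound 3 at 26.6% leaves less room for a drop of the same size. Compound 4 is therefore expected to give about 12% in this assay, most likely between 3% and 24%.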

Compound 4, a percentage reported as activity, at one concentration (the size of the read-out at that concentration, not a potency): 33.6%
The estimate for compound 4 lay 21.6 percentage points below the measured number, and the stated range ends below it.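

On the core of compound 3, hydroxy to methoxy gave a number 7 percentage points higher from compound 3 to compound 4 (within the scatter), so the step seen on the core of compound 1 did not carry over in this assay: the same change on two cores in this assay, a number 18.1 percentage points lower (beyond the scatter) from compound 1 to compound 2 and a number 7 percentage points higher (within the scatter) from compound 3 to compound 4, 25.1 percentage points apart, beyond the scatter of two such steps

Methoxy in place of hydrogen on an aromatic carbon gave a number 14.1 percentage points higher from compound 2 to compound 4 (beyond the scatter), and this change did not carry over from one core to the other either: the same change on two cores in this assay, a number 11 percentage points lower (beyond the scatter) from compound 1 to compound 3 and a number 14.1 percentage points higher (beyond the scatter) from compound 2 to compound 4, 25.1 percentage points apart, beyond the scatter of two such steps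

Within these four compounds, the outcome of each change therefore depends on the core that carries it, but the data do not show the reason for this or whether it extends to any other core.

Open, on these data alone, is how an ethoxy group or an amine in place of the methoxy would read in this assay, and whether the same dependence on the core would appear with those groups. Also open, as far as these compounds go, is whether the stronger and weaker effects seen at this single concentration would hold at other concentrations.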